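Amino Substitution on a Pyridine Amide Core

This account rests on a few compounds, and the source may have more. Where it says the series, first, only, none or still open, it means among the compounds named here.

Compound 1 `CN(C)c1nc(N)c(C(=O)Nc2ccccn2)nc1Cl` and compound 2 `CN(C)c1ncc(C(=O)Nc2ccccn2)nc1Cl` share one core and differ by amino in place of hydrogen on an aromatic carbon. In an assay on Ltk cells for inhibition of metabotropic glutamate receptor 5 (Homo sapiens), read by fluorescence (on this read-out lower numbers stand for stronger inhibition and higher numbers for weaker inhibition), compound 1 gives 134 nM, and compound 2 gives 158 nM; the step of a 1.2-fold lower number from compound 2 to compound 1 (0.07 log units; within the scatter) shows the two within the scatter of each other. Compound 3 `Cc1cccc(NC(=O)c2cccc(C)n2)n1` is built on a different core, and the difference between the two cores is not broken down here. In this assay compound 3 gives 32 nM, the strongest inhibition of the three, beyond the scatter from both compound 1 and compound 2.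

Compound 4 `Cc1cccc(NC(=O)c2nc(C)ccc2N)n1` differs from compound 3 by amino in place of hydrogen on an aromatic carbon. This is the same kind of change as that from compound 2 to compound 1, though the surroundings differ: in compound 1 the amino sits on a six-membered aromatic ring with 2 nitrogen, next to the ring nitrogen, ortho to a group of 9 heavy atoms, meta to a dimethylamino group and para to a chloro group, while in compound 4 it sits on a six-membered aromatic ring with 1 nitrogen, ortho to a large group and para to a methyl group. Because the earlier step of a 1.2-fold lower number from compound 2 to compound 1 (0.07 log units; within the scatter) stayed within the scatter, the step to compound 4 is expected to be small, a 1.1-fold lower number from compound 3 to compound 4 (0.03 log units; within the scatter). Compound 4 is therefore estimated at 30 nM, with a range from 12 nM to 75 nM.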

Compound 4, half-maximal inhibitory concentration: 22 nM
The estimate for compound 4 lay 1.4-fold (0.13 log units) above the measured number; the measured number falls inside the stated range.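

In this assay, amino in place of hydrogen on an aromatic carbon gives a 1.5-fold lower number from compound 3 to compound 4 (0.16 log units; within the scatter), so on this core too the change leaves the number within the scatter. Set beside the earlier step, the change carries from one core to the other with no difference that can be read: the same change on two cores in this assay, a 1.2-fold lower number (0.07 log units; within the scatter) from compound 2 to compound 1 and a 1.5-fold lower number (0.16 log units; within the scatter) from compound 3 to compound 4, 1.2-fold (0.09 log units) apart, within the scatter of two such steps This agreement rests on only two pairs in one assay, so it shows that the amino group left the number within the scatter on these two cores, but it does not show that the same would hold on a further core, nor does it give the amino group any effect of its own.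

The compounds shown leave open whether a methylamino, hydroxyl or methoxy group on the same aromatic carbon would move the number beyond the scatter on either core. They also leave open which single changes make up the difference between the two cores.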